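Fluorophenyl swap from compound 3 to compound 4

The source may hold more compounds than are shown below. What is called first, only, known or untested is meant among the compounds shown, and "the series" means these compounds.

Measured in a physicochemical assay for lipophilicity; a lower number here means a more polar compound, a higher number a more lipophilic compound:
Compound 1 `CC(C)(C)n1ncc(OCc2nnc(-c3cc(F)c(F)cc3F)o2)c(Cl)c1=O`: 2.96
Compound 2 `CC(C)(C)n1ncc(OCc2nnc(-c3c(F)cccc3F)o2)c(Cl)c1=O`: 2.75
Compound 3 `CC(C)(C)n1ncc(OCc2nnc(-c3ccc(F)cc3)o2)c(Cl)c1=O`: 2.69

Compound 3 has no step beyond the scatter to either of the other two compounds in this assay. The gaps are a number 0.06 log units lower from compound 2 to compound 3 (within the scatter) and a number 0.27 log units lower from compound 1 to compound 3 (within the scatter). The third measured step, a number 0.21 log units lower from compound 1 to compound 2 (within the scatter), also stays inside the scatter.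

The next compound is compound 4 `CC(C)(C)n1ncc(OCc2nnc(-c3ccccc3F)o2)c(Cl)c1=O`. The change is 2-fluorophenyl in place of 4-fluorophenyl on an aromatic carbon. The two have the same atoms, joined differently.

All three measured steps exchange the group on this same aromatic carbon, so they are the ones that bear on the change. However, no measured pair has the same atoms joined differently. With compound 3 at 2.69 and every measured step within the scatter, no step beyond the scatter is expected in this assay. The expected step is a number 0.01 log units higher from compound 3 to compound 4 (within the scatter). For compound 4 the estimated value is 2.7, with an expected range of 2.4 to 3.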

Compound 4, partition coefficient: 2.89
For compound 4 the middle estimate is 0.19 log units below the measured one, within the range that was stated.
By their numbers in this assay, from the lowest: compounds 3, 2, 4 and 1 (each within the scatter of the next).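

Within the data shown here, the exchange of 4-fluorophenyl for 2-fluorophenyl gives a number 0.20 log units higher from compound 3 to compound 4 (within the scatter) in this assay and is the first measured pair at this position with the same atoms joined differently, so a rearrangement of this kind also stays inside the scatter. Hydrogen in place of fluoro gives a number 0.14 log units higher from compound 2 to compound 4 (within the scatter) and 2-fluorophenyl in place of 2,4,5-trifluorophenyl gives a number 0.07 log units lower from compound 1 to compound 4 (within the scatter), so among the four compounds neither the place nor the number of fluoro groups on the phenyl produces a step beyond the scatter. Nothing available accounts for these small differences.

Still open, as far as these compounds go, is whether any group at this position can produce a step beyond the scatter in this assay, for example a phenyl carrying an amine or a carboxylic acid in place of fluoro. Also open, from the compounds shown here alone, is whether a longer chain in place of the phenyl would do so.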